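The source may report more compounds than this note shows. Statements on the series, on what has been measured and on what is new or still open speak of the compounds shown alone.

In a functional assay on Bel-7402 cells (Homo sapiens) for inhibition, read by MTT assay, with a stated time of 24 h, tested at 0.1 ug/mL (a lower number here means less inhibition of growth, a higher number more inhibition of growth at the concentration tested), compound 1 (`O=C(CCCCC(S)CCS)NO`) gives 5.96% and compound 2 (`O=C(CCCCC1CCSS1)Nc1ccccn1`) gives 0.89%, while compound 3 (`O=C(CCCCC(S)CCS)Nc1ccccc1`) gives 0.85% at the single concentration tested. These three values lie within the scatter of one another, so compound 3 holds no distinct rank. Compound 4 (`O=C(CCCCC(S)CCS)Nc1ccccn1`) follows from compound 3 with pyridin-2-yl in place of phenyl on an amide-type nitrogen. For the measured compounds named here, the only measured step on that nitrogen stays within the scatter (a number 5.1 percentage points lower from compound 1 to compound 3 (within the scatter)). Compound 2 already carries pyridin-2-yl there, with 0.89% on a different remainder. No step beyond the scatter is therefore expected in this assay in either direction. The estimated step is small (a number 1.2 percentage points higher from compound 3 to compound 4 (within the scatter)). Compound 4 is estimated at 2% within an expected range (0% to 9%).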

Compound 4, percent growth inhibition at one concentration: "not active" (no number reported)
The entry for compound 4 holds no number; the estimate stays without a comparison.
By their numbers in this assay, from the lowest: compounds 3, 2 and 1 (each within the scatter of the next).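

For the compounds shown here, compound 4 is entered as "not active" without a number, so no step from compound 3 can be read. The compounds shown leave open what pyridin-2-yl in place of phenyl does to growth inhibition. No measured evidence bears on this result.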